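One Chlorine Fewer on the Amide: Expected Solubility

A few compounds are considered here, and "the series" means these few. Any claim that something is new, unique, unknown or untested is made for them only; others in the source may bear on it.

Compound 1 `C/C=C/C(=O)Nc1cccc(-c2nc3ccccc3s2)c1` gives 110 nM in a physicochemical assay for solubility, in phosphate buffer, measured as kinetic solubility, with a stated time of 18 h, at pH 7.4; on this read-out higher numbers stand for higher solubility and lower numbers for lower solubility. Compound 2 `C=C(C)C(=O)Nc1cccc(-c2nc3ccccc3s2)c1` gives 420 nM. Compound 3 `O=C(Nc1cccc(-c2nc3ccccc3s2)c1)c1ccc(Cl)nc1Cl` gives 350 nM.

Compound 3 stands second highest of the three: the step of a 1.2-fold lower number from compound 2 to compound 3 (0.08 log units; within the scatter) lies within the scatter, whereas the step of a 3.2-fold higher number from compound 1 to compound 3 (0.50 log units; beyond the scatter) lies beyond it. Compound 4 `O=C(Nc1cccc(-c2nc3ccccc3s2)c1)c1ccncc1Cl` differs from compound 3 in one place: 3-chloropyridin-4-yl in place of 2,6-dichloropyridin-3-yl on a carbonyl carbon. Within the data shown here, no measured step removes a chlorine or shifts the point where the ring joins the carbonyl; the steps of a 3.2-fold higher number from compound 1 to compound 3 (0.50 log units; beyond the scatter) and a 1.2-fold lower number from compound 2 to compound 3 (0.08 log units; within the scatter) swap whole groups and only show that amides of this kind sit close together. Compound 4 is therefore expected to show a step of a 1.3-fold higher number from compound 3 to compound 4 (0.11 log units; within the scatter), not beyond the scatter. The estimate for compound 4 is 450 nM, between 200 nM and 1000 nM.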

Compound 4, solubility: 320 nM
For compound 4 the middle estimate is 1.4-fold (0.15 log units) above the measured one; the range from low to high includes it.
By their numbers in this assay, from the lowest: compound 1; then compounds 4, 3 and 2 (each within the scatter of the next).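

Taking away a chlorine and shifting the point where the ring joins the carbonyl carbon, a change no earlier step isolated, moves the number in this assay only within the scatter (a 1.1-fold lower number from compound 3 to compound 4 (0.04 log units; within the scatter)). The new group sits level with 1-methylethenyl (a 1.3-fold lower number from compound 2 to compound 4 (0.12 log units; within the scatter)) and apart from prop-1-en-1-yl (a 2.9-fold higher number from compound 1 to compound 4 (0.46 log units; beyond the scatter)), so this position has so far tolerated both aromatic rings.

The compounds shown leave open whether an amine or a carboxylic acid on this ring would change the number. Nothing given here explains why these groups sit so close.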